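Notes on the ring-amine substituent step to compound 3

The source may report more compounds than this note shows. Statements on the series, on what has been measured and on what is new or still open speak of the compounds shown alone.

Compound 1 `COc1cc(N)c(Cl)cc1NC(=O)C1CCN(C2CCCC2)CC1` and compound 2 `COc1cc(N)c(Cl)cc1NC(=O)C1CCN(CC2CC2)CC1` share one core and differ only in the group on the ring amine nitrogen. In a functional assay on the whole organism for antagonist activity, with Mus musculus as the target (a lower number here means that less compound is needed, a higher number that more compound is needed for the effect), compound 1 gives > 10 mg/kg, which is a limit of the assay and not a number. In this assay compound 2 gives > 10 mg/kg, again a limit. The step that the two limits leave unreadable from compound 1 to compound 2 therefore cannot be read; what the two compounds share is the limit of > 10 mg/kg in this assay, at which 2 of the 2 values shown sit. Compound 2 thus stands at that limit, with no number of its own.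

Compound 3 `COc1cc(N)c(Cl)cc1NC(=O)C1CCN(C/C=C/c2ccccc2)CC1` carries the change (2-phenylethenyl in place of cyclopropyl on a saturated chain carbon bound to an amine nitrogen in a ring). Within the data shown here, no readable measured step bears on this change, since the only step sits between two limits. The expectation rests on the limit of compound 2 alone. Compound 3 is estimated at 10 mg/kg, within a range of 2 mg/kg to 40 mg/kg. The expected step of a number no higher from compound 2 to compound 3 (the limit leaves the size open) is set near zero, and a limit remains the most likely report.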

Compound 3, dose for half-maximal effect: > 10 mg/kg
Compound 3: only a limit was reported; the forecaster's own chance of this, stated with the estimate: 60%; the middle value sits exactly at the limit.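

In this assay no step can be read among compound 1, compound 2 and compound 3, whose results are all limits of the assay and not numbers: the limit of > 10 mg/kg in this assay, at which 3 of the 3 values shown sit. The compounds shown leave open whether any group on the ring amine nitrogen gives a readable half-maximal dose.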